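The source may report more compounds than this note shows. Statements on the series, on what has been measured and on what is new or still open speak of the compounds shown alone.

Measured compounds in the series so far:

compound 1, `Cc1c(Cl)cccc1C(=O)NC(CCN(C)C)c1ccc(Cl)cc1`: 142%
compound 2, `Cc1ccc(C)c(C(=O)NC(CCN(C)C)c2ccc(Cl)cc2)c1`: 164%
compound 3, `Cc1cc(C)c(C(=O)NC(CCN(C)C)c2ccc(Cl)cc2)cc1C`: 159%

In an assay on NIH3T3 cells with Urotensin-2 receptor (Homo sapiens) as the target (on this read-out lower numbers stand for smaller maximal responses and higher numbers for larger maximal responses), compound 3 sits at 159%. Its nearest neighbour on the numbers is compound 2, and a number 5 percentage points lower from compound 2 to compound 3 (within the scatter), so these two cannot be told apart. Going by the values given here, its furthest neighbour is compound 1, which lies below compound 3 by more than the scatter; that gap has no single-point step of its own, and the two values are all that can be said of it. Among the compounds with values here, the one step that does separate numbers cleanly is a number 22 percentage points higher from compound 1 to compound 2 (beyond the scatter).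

Compound 4, `Cc1ccc(C(=O)NC(CCN(C)C)c2ccc(Cl)cc2)c(C)c1`, is the next member. It differs from compound 3 in one place: hydrogen in place of methyl on an aromatic carbon.

Within the data shown here, the step that bears on this change is the one from compound 2 to compound 3, where a methyl was also swapped against a hydrogen on an aromatic carbon of the same ring, and a number 5 percentage points lower from compound 2 to compound 3 (within the scatter). That change left this assay essentially unmoved. The present step removes a methyl from a different aromatic carbon of that ring, so it is not the exact reverse, but it is of the same kind and size. The expectation for compound 4 is therefore a step of a number 1 percentage points higher from compound 3 to compound 4 (within the scatter), i.e. none beyond the scatter. Compound 4 is estimated at 160%, within a range of 140% to 180%.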

Compound 4, largest response reached (reported as efficacy), in percent of the reference or control that the assay uses: 147%
Estimate against measurement, compound 4: 13 percentage points above, within the range that was stated.
By their numbers in this assay, from the lowest: compounds 1 and 4 (each within the scatter of the next); then compounds 3 and 2 (each within the scatter of the next).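

In this assay the aromatic carbon para to a methyl group and meta to a large group turns out to matter: a number 12 percentage points lower from compound 3 to compound 4 (beyond the scatter) when its methyl gives way to hydrogen, whereas the methyl change on another carbon of the same ring, in the step from compound 2 to compound 3, stayed within the scatter. The arrangement of the two methyl groups also counts, since a number 17 percentage points lower from compound 2 to compound 4 (beyond the scatter) on exchanging 2,5-dimethylphenyl for 2,4-dimethylphenyl, so these two groups can be told apart on this read-out. The exchange of 3-chloro-2-methylphenyl for 2,4-dimethylphenyl gives no such separation, with a number 5 percentage points higher from compound 1 to compound 4 (within the scatter) in that case.

The compounds shown leave open whether the higher numbers depend on methyl itself at this carbon, or whether a chlorine, an ethyl or a methoxy there would serve equally. They also leave open whether the same sensitivity would hold with a longer chain in place of the dimethylaminoethyl part of the core. Nothing at hand accounts for the size of these steps.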